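Sulfur substituent change on the shared core: compound 4

The source may report more compounds than this note shows. Statements on the series, on what has been measured and on what is new or still open speak of the compounds shown alone.

Compound 1 `CC(C(=O)NCc1ccc(C(F)(F)F)nc1SCCOc1ccccc1)c1ccc(NS(C)(=O)=O)c(F)c1` is the reference point of this small set. In an assay on CHO-K1 cells for antagonist activity at transient receptor potential cation channel subfamily V member 1 (Homo sapiens), read by FLIPR (on this read-out higher numbers stand for weaker inhibition and lower numbers for stronger inhibition), compound 1 gives 2.3 nM, the lowest number among the two compounds with a value. Compound 2 `COC(=O)CCSc1nc(C(F)(F)F)ccc1CNC(=O)C(C)c1ccc(NS(C)(=O)=O)c(F)c1` gives 48.2 nM, and the step of a 21-fold higher number from compound 1 to compound 2 (1.32 log units; beyond the scatter) shows that a change on the chain that hangs from the sulfur costs a good deal. Compound 3 `CC(C(=O)NCc1ccc(C(F)(F)F)nc1[S+]([O-])C1CCCCC1)c1ccc(NS(C)(=O)=O)c(F)c1` is reported as "not active" (no number reported), with no number to compare.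

Compound 4 `CC1CCC(Sc2nc(C(F)(F)F)ccc2CNC(=O)C(C)c2ccc(NS(C)(=O)=O)c(F)c2)CC1` carries the change (4-methylcyclohexyl in place of 2-phenoxyethyl on a sulfur). For the measured compounds named here, no measured step matches this change directly; the only step on this side of the core, from compound 1 to compound 2, was large and unfavourable, and it concerned a different part of the chain, so it bears on compound 4 only as a hint that the sulfur substituent matters. A loss beyond the scatter is therefore expected, estimated as a 4.3-fold higher number from compound 1 to compound 4 (0.64 log units; beyond the scatter), smaller than that seen for compound 2. Compound 4 is expected to give about 10 nM, within a range of 2.5 nM to 50 nM.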

Compound 4, inhibition constant: 0.5 nM
Compound 4: middle estimate off by 20-fold (1.30 log units), on the high side, outside the stated range (below it).
By their numbers in this assay, from the lowest: compound 4; then compound 1; then compound 2.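

Putting 4-methylcyclohexyl in place of 2-phenoxyethyl on the sulfur gives a 4.6-fold lower number from compound 1 to compound 4 (0.66 log units; beyond the scatter) in this assay, so among these compounds, low numbers at this position do not require an aromatic ring or a hydrogen-bond acceptor in the substituent. Against the 2-(methoxycarbonyl)ethyl chain, the same ring gives a 96-fold lower number from compound 2 to compound 4 (1.98 log units; beyond the scatter) and sets the lowest number of the series so far, showing that this position spans a wide range with the sulfur unchanged. Nothing at hand explains why the saturated ring gives the lower number.

Going by these compounds, whether the methyl group on the ring contributes stays open, as does the outcome with a cyclopentyl ring or a 2-aminoethyl chain on the sulfur. Compound 3 differs from compound 4 in more than one place, so its missing number cannot be assigned to either change.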